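The source may hold more compounds than are shown below. What is called first, only, known or untested is meant among the compounds shown, and "the series" means these compounds.

In a functional assay on SMMC-7721 cells (Homo sapiens) for cytotoxicity, read by MTT assay, with a stated time of 4 days (on this read-out lower numbers stand for stronger inhibition and higher numbers for weaker inhibition), compound 1 `C=C1C[C@]23C[C@@]1(O)CC[C@H]2c1ccc(OS(=O)(=O)c2ccc(C)cc2)c(C)c1[C@@H]3Cn1cc(-c2ccc(Cl)cc2)nn1` returns only the assay limit, > 20000 nM. Compound 2 `C=C1C[C@]23C[C@@]1(O)CC[C@@H]2c1cccc(C)c1[C@@H]3Cn1cc(-c2ccc(OC)cc2)nn1` likewise gives no number in this assay, only the limit > 20000 nM. For the measured compounds named here, both results rest on (the limit of > 20000 nM in this assay, at which 2 of the 2 values shown sit), so compound 2 stands at the limit and no measured step exists within the pair. Compound 3 `C=C1C[C@]23C[C@@]1(O)CC[C@@H]2c1cccc(C)c1[C@@H]3Cn1cc(-c2ccc(Br)cc2)nn1` differs from compound 2 by bromo in place of methoxy on an aromatic carbon. With nothing but limits to go on, no step beyond the scatter is expected, a step that the limit leaves unreadable from compound 2 to compound 3. Compound 3 is estimated at 30000 nM, in the range 10000 nM to 100000 nM, most likely again reported as a limit.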

Compound 3, half-maximal inhibitory concentration: > 20000 nM
Compound 3: only a limit was reported; the forecaster's own chance of this, stated with the estimate: 80%; the middle value is on the limit's open side.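

Compound 2 and compound 3 both stand at a limit rather than a number, so no step can be read for bromo in place of methoxy: the limit of > 20000 nM in this assay, at which 3 of the 3 values shown sit.

Going by these compounds, whether any other group in this place gives a readable value in this assay remains open.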